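A few compounds are considered here, and "the series" means these few. Any claim that something is new, unique, unknown or untested is made for them only; others in the source may bear on it.

Compound 1 `BrCCCCCCOc1c(Br)cc(Br)cc1Oc1ccc(Br)cc1Br` gives 33.8 ug/mL in a functional assay on U-937 cells (Homo sapiens) for cytotoxicity, read by MTT assay, with a stated time of 24 h (on this read-out higher numbers stand for weaker inhibition and lower numbers for stronger inhibition), and holds no separate place there. Compound 2 `COc1ccccc1N1CCN(CCCCCOc2c(Br)cc(Br)cc2Oc2ccc(Br)cc2Br)CC1` gives 37.5 ug/mL and compound 3 `CC(C)(C)OC(=O)N1CCN(CCCCCOc2c(Br)cc(Br)cc2Oc2ccc(Br)cc2Br)CC1` gives 35.5 ug/mL in this assay and all three values lie within the scatter of one another. Compound 4 `OCCOc1c(Br)cc(Br)cc1Oc1ccc(Br)cc1Br` differs from compound 1 by hydroxy in place of 4-bromobutyl on a saturated chain carbon, two bonds along the chain from an oxygen on an aromatic ring. Among the compounds with values here, the only measured step (a 1.1-fold lower number from compound 2 to compound 3 (0.02 log units; within the scatter)) lies within the scatter, but it sits on an amine nitrogen in a ring and not at this place, so it bears on the change only indirectly. Within the data shown here, no measured compound carries the hydroxy group. With compound 1 at 33.8 ug/mL as the starting point, the estimated change (a 1.1-fold higher number from compound 1 to compound 4 (0.05 log units; within the scatter)) is expected to stay within the scatter, with no firm direction. The estimate for compound 4 is 38 ug/mL (expected range 17 ug/mL to 85 ug/mL).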

Compound 4, half-maximal inhibitory concentration: 34.5 ug/mL
Compound 4: middle estimate off by 1.1-fold (0.04 log units), on the high side; the range from low to high includes it.
By their numbers in this assay, from the lowest: compounds 1, 4, 3 and 2 (each within the scatter of the next).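

Within the data shown here, replacing the 4-bromobutyl group with hydroxy at this position in this assay gives a 1.0-fold higher number from compound 1 to compound 4 (0.01 log units; within the scatter) and is the first measured change on the chain itself, as the earlier step sat on an amine nitrogen in a ring. The change removes the bromine, cuts the 6-bromohexyl chain down to 2-hydroxyethyl and brings in a hydrogen-bond donor and acceptor, yet the number stays within the scatter, so neither the chain length nor the terminal bromine is shown to matter in this cell read-out between these two compounds. No supporting measurement is available to explain this result.

As far as these compounds go, whether a 6-hydroxyhexyl chain, which would separate chain length from the end group, would behave the same remains open. So does the effect of an amine or a carboxylic acid at the end of the short 2-carbon chain.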